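A few compounds are considered here, and "the series" means these few. Any claim that something is new, unique, unknown or untested is made for them only; others in the source may bear on it.

Measured in a functional assay on Raji cells (Homo sapiens) for cytotoxicity, with a stated time of 72 h; on this read-out lower numbers stand for an effect already at smaller amounts and higher numbers for an effect only at larger amounts of compound:
- Compound 1 `C=C[C@@](C)(/C=C/c1ccc(Nc2ccc(OC)cc2)cc1)CCC=C(C)C`: > 26000 nM, a limit
- Compound 2 `C=C[C@@](C)(/C=C/c1ccc(Nc2ccc(OC(F)(F)F)cc2)cc1)CCC=C(C)C`: > 26000 nM, a limit
- Compound 3 `C=C[C@@](C)(/C=C/c1ccc(Nc2ccc(Cl)cc2)cc1)CCC=C(C)C`: > 26000 nM, a limit

None of the three compounds has a numerical value, and the series as a whole stands at the limit of > 26000 nM in this assay, at which 3 of the 3 values shown sit. Compound 3 therefore has only a limit, > 26000 nM, and it shares this position with the other two compounds.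

The next compound is compound 4 `C=C[C@@](C)(/C=C/c1ccc(Nc2ccc(C(F)(F)F)cc2)cc1)CCC=C(C)C`, which carries trifluoromethyl in place of chloro on an aromatic carbon, para to a large group: trifluoromethyl in place of chloro on an aromatic carbon. The measured step closest to this change is a step that the two limits leave unreadable from compound 2 to compound 3. The step of the same kind is a step that the two limits leave unreadable from compound 1 to compound 3, and the remaining one is a step that the two limits leave unreadable from compound 1 to compound 2. None of the three has a size that can be read, so they offer no magnitude or direction to carry over. No step beyond the usual scatter is therefore expected in this assay, and no direction can be assigned to one.

Compound 4 is expected to remain in the same region as the others, given (the limit of > 26000 nM in this assay, at which 3 of the 3 values shown sit), and it may well be reported only as a limit. The expected step is a number no higher from compound 3 to compound 4 (the limit leaves the size open). For compound 4 the estimated value is 26000 nM, with an expected range from 10000 nM to 40000 nM.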

Compound 4, half-maximal effective concentration: > 26000 nM
Compound 4: a limit, no number; the forecaster's own chance of this, stated with the estimate: 80%; the middle value lies on the limit itself.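

In this assay compound 4 gives > 26000 nM, a limit and not a number. Its steps from compound 1, compound 2 and compound 3 therefore cannot be read: the limit of > 26000 nM in this assay, at which 4 of the 4 values shown sit.

The compounds shown leave open whether any of these four groups on the shared core changes the read-out at all, and in which direction.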